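Swapping a pyrrole for a methylthiophene on a weak series

The source may report more compounds than this note shows. Statements on the series, on what has been measured and on what is new or still open speak of the compounds shown alone.

Three compounds share one core and differ only in the aromatic ring attached to a saturated chain carbon bound to an amide-type nitrogen. In an assay on HEK293 cells for agonist activity at transient receptor potential cation channel subfamily M member 8 (Homo sapiens), read by fluorescence and calcium flux, with a stated time of 15 min (on this read-out lower numbers stand for an effect already at smaller amounts and higher numbers for an effect only at larger amounts of compound), compound 1 `CCN(Cc1c[nH]nn1)C(=O)COc1ccc(C)cc1` gives 31100 nM, compound 2 `CCN(Cc1cccnc1)C(=O)COc1ccc(C)cc1` gives 15400 nM, and compound 3 `CCN(Cc1cc[nH]c1)C(=O)COc1ccc(C)cc1` gives 21800 nM. Compound 3 thus holds the second highest of the three numbers, and its distances to both neighbours lie within the scatter. The steps among them are small: a 2.0-fold lower number from compound 1 to compound 2 (0.31 log units; beyond the scatter), a 1.4-fold lower number from compound 1 to compound 3 (0.15 log units; within the scatter), and a 1.4-fold higher number from compound 2 to compound 3 (0.15 log units; within the scatter).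

Compound 4 `CCN(Cc1ccc(C)s1)C(=O)COc1ccc(C)cc1` carries the change (5-methylthiophen-2-yl in place of 1H-pyrrol-3-yl on a saturated chain carbon bound to an amide-type nitrogen). Going by the values given here, no measured step involves the entering ring; the only step beyond the scatter, a 2.0-fold lower number from compound 1 to compound 2 (0.31 log units; beyond the scatter), also removed a ring with a hydrogen-bond donor, while a 1.4-fold higher number from compound 2 to compound 3 (0.15 log units; within the scatter) stayed within the scatter. In this assay compound 4 is therefore expected to show at most a modest movement, a 1.5-fold lower number from compound 3 to compound 4 (0.16 log units; within the scatter), toward a lower number. The estimate for compound 4 is 15000 nM, with a range from 5000 nM to 45000 nM.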

Compound 4, half-maximal effective concentration: 178 nM
Compound 4: middle estimate off by 84-fold (1.93 log units), on the high side; the whole stated range lies above it.
By their numbers in this assay, from the lowest: compound 4; then compounds 2, 3 and 1 (each within the scatter of the next, the first and the last beyond it).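

In this assay the ring on this saturated chain carbon bound to an amide-type nitrogen matters far more than the three earlier compounds suggested. The 5-methylthiophen-2-yl group gives large steps against all three earlier rings (a 120-fold lower number from compound 3 to compound 4 (2.09 log units; beyond the scatter)), (an 87-fold lower number from compound 2 to compound 4 (1.94 log units; beyond the scatter)) and (a 170-fold lower number from compound 1 to compound 4 (2.24 log units; beyond the scatter)), so compound 4 stands clearly apart from a group whose numbers lay close together. Nothing available here explains why this ring has such an effect.

The change brings in a sulfur-containing ring and a methyl group at once, so the compounds shown cannot tell which of the two carries the drop. A plain thiophen-2-yl ring, a 5-methylfuran-2-yl ring or a 5-ethylthiophen-2-yl ring at the same place would help to separate these two parts.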